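The source may report more compounds than this note shows. Statements on the series, on what has been measured and on what is new or still open speak of the compounds shown alone.

Measured so far:
Compound 1 `COc1ccc(-c2cnc3nc(N)nc(N4CCN(Cc5ccccc5F)CC4)c3n2)cc1OC` — in a functional assay on cells (T-cell, Homo sapiens) for inhibition (a higher number here means a weaker inhibitor, a lower number a stronger inhibitor), compound 1 gives 700 nM.
Compound 2 `COc1ccc(-c2cnc3nc(N)nc(N4CCN(C(=O)Nc5ccc(C#N)cc5)CC4)c3n2)cc1OC` — in this assay compound 2 gives 74 nM.

Compound 2 has the lower of these two numbers and is therefore the stronger inhibitor of the pair. Among the measured compounds shown here, the only step measured so far is a 9.5-fold lower number from compound 1 to compound 2 (0.98 log units; beyond the scatter), in which the whole group on the ring amine was exchanged for another. Compound 3 `COc1ccc(-c2cnc3nc(N)nc(N4CCN(C(=O)Nc5ccccc5)CC4)c3n2)cc1OC` keeps the carbamoyl group of compound 2 and differs from it only in this: hydrogen in place of cyano on an aromatic carbon. For the measured compounds named here, no measured step removes a single small group from an otherwise unchanged piece, so the step from compound 1 to compound 2 bears only loosely on this case: it shows that the group on the ring amine matters, not how much the cyano alone contributes. A small weakening is expected, so compound 3 is estimated at 150 nM, within 50 nM to 450 nM. The expected step of a 2.0-fold higher number from compound 2 to compound 3 (0.31 log units; beyond the scatter) may well fall within the scatter.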

Compound 3, half-maximal inhibitory concentration: 3.4 nM
Compound 3: middle estimate off by 44-fold (1.64 log units), on the high side, and the stated range ends above it.
By their numbers in this assay, from the lowest: compound 3; then compound 2; then compound 1.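

In this assay, the group on this aromatic carbon carries far more weight than the earlier pair could reveal: hydrogen in place of cyano gives a 22-fold lower number from compound 2 to compound 3 (1.34 log units; beyond the scatter). With the unsubstituted phenyl ring, the exchange of 2-fluorobenzyl for the carbamoyl group now reads as a 210-fold lower number from compound 1 to compound 3 (2.31 log units; beyond the scatter), so the step measured with the cyano present showed only part of what that exchange can give. No measurement here explains why removing the cyano has so large an effect.

The compounds shown leave open whether cyano is a special case or whether any group on this carbon weakens inhibition. A fluorine, a methyl or a methoxy in the same place, para to the large group, would help to separate these two readings.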